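Swapping a Furan for a Nitrile on a Shared Core

This account rests on a few compounds, and the source may have more. Where it says the series, first, only, none or still open, it means among the compounds named here.

Three analogues built on the same two-ring core have been examined in an ADME assay on HEL cells (Homo sapiens) for cytotoxicity, with a stated time of 3 days; a lower number here means that less compound is tolerated, a higher number that more compound is tolerated. Compound 1 `Cc1cc(-c2ccco2)cn2c(CSCCc3ccccc3)cnc12` gives 40 ug/mL in this assay. Compound 2 `Cc1cc(Sc2ccc(N)cc2)cn2c(CSCCc3ccccc3)cnc12` gives 23 ug/mL. Compound 3 `Cc1cc(-c2ccco2)c2ncc(CSCCc3ccccc3)n2c1` gives 41 ug/mL, and none of these three numbers stands apart from the others beyond the scatter, so compound 3 is not distinguished from compound 1 or compound 2 on the evidence so far.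

The next compound, compound 4 `Cc1cc(C#N)c2ncc(CSCCc3ccccc3)n2c1`, carries cyano in place of furan-2-yl on an aromatic carbon. For the measured compounds named here, only one measured step speaks to a change at this aromatic carbon: a 1.7-fold lower number from compound 1 to compound 2 (0.24 log units; within the scatter), in which a group of a different kind displaced the same furan-2-yl on the core of compound 1 and the number barely moved. That step comes from a different isomer of the core and introduces a larger group than cyano, so it is an indirect guide, but it offers no sign that replacing the furan-2-yl shifts tolerance in this assay.

Compound 4 is therefore expected to fall close to compound 3, with a 1.0-fold lower number from compound 3 to compound 4 (0.01 log units; within the scatter) estimated to lie within the scatter. The estimate for compound 4 is 40 ug/mL, with a range from 20 ug/mL to 80 ug/mL.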

Compound 4, half-maximal cytotoxic concentration: > 100 ug/mL
Compound 4: no number, only a limit (the forecaster's own chance of this, stated with the estimate: 10%); middle value at least 2.5-fold (0.39 log units) away from the limit.
By their numbers in this assay, from the lowest: compounds 2, 1 and 3 (each within the scatter of the next). At a limit, above all of these: compound 4.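

In this assay compound 4 gives > 100 ug/mL, which is a limit of the assay and not a number. The step, an at least 2.4-fold higher number from compound 3 to compound 4 (0.38 log units; beyond the scatter), is the only one shown that lies beyond the scatter, so this aromatic carbon, ortho to a fused ring and two atoms from the ring nitrogen, is a place where exchanging one group for another can change how much compound is tolerated, something that a 1.7-fold lower number from compound 1 to compound 2 (0.24 log units; within the scatter) gave no sign of on the other isomer of the core. Only the lower bound of this step is known, and its full size cannot be read: the limit of > 100 ug/mL in this assay, at which 1 of the 4 values shown sits.

The compounds shown leave open whether the step reflects the loss of furan-2-yl or the arrival of cyano, a question that a small group such as a methyl, a chlorine or an amine at this same carbon would help to settle. They also leave open whether cyano in place of furan-2-yl on the core of compound 1 would give a comparable step, or whether a carboxylic acid or an amide at this carbon would behave as cyano does.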